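A few compounds are considered here, and "the series" means these few. Any claim that something is new, unique, unknown or untested is made for them only; others in the source may bear on it.

Measured compounds: compound 1 `Nc1scc(CN2CCN(c3cc(Cl)cc(Cl)c3)CC2)c1C(=O)c1ccc(Cl)cc1`, compound 2 `COc1ccc(N2CCN(Cc3csc(N)c3C(=O)c3ccc(Cl)cc3)CC2)cc1`, compound 3 `Nc1scc(CN2CCN(c3ccc([N+](=O)[O-])cc3)CC2)c1C(=O)c1ccc(Cl)cc1`.

In a functional assay on CHO cells with adenosine receptor A1 (Homo sapiens) as the target, read by cAMP accumulation and immunoassay, with a stated time of 6 min, tested at 1 uM (a higher number here means a weaker effect of the compound at the concentration tested, a lower number a stronger effect), compound 1 gives -69%. Compound 2 gives -15% and compound 3 gives -8.3%. Compound 3 thus stands apart from compound 1 by a number 60.7 percentage points higher from compound 1 to compound 3 (beyond the scatter), while the other gap, a number 6.7 percentage points higher from compound 2 to compound 3 (within the scatter), is within the scatter.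

Compound 4 `Nc1scc(CN2CCN(c3ccccc3C(F)(F)F)CC2)c1C(=O)c1ccc(Cl)cc1` differs from compound 3 at the ring nitrogen: 2-(trifluoromethyl)phenyl in place of 4-nitrophenyl on an amine nitrogen in a ring. For the measured compounds named here, the steps that bear on this are the two exchanges of the aryl group, a number 54 percentage points higher from compound 1 to compound 2 (beyond the scatter) and a number 60.7 percentage points higher from compound 1 to compound 3 (beyond the scatter), both large; the exchange of one substituent for another on the same aryl, a number 6.7 percentage points higher from compound 2 to compound 3 (within the scatter), stayed within the scatter. Going by the values given here, no measured compound carries 2-(trifluoromethyl)phenyl, so the step from compound 3 is estimated as a number 16.7 percentage points lower from compound 3 to compound 4 (beyond the scatter), downward but uncertain. Compound 4 is expected to give -25%, between -65% and 5%.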

Compound 4, a percentage reported as activity, at one concentration (the size of the read-out at that concentration, not a potency): -39%
The estimate for compound 4 lay 14 percentage points above the measured number; the measured number falls inside the stated range.
By their numbers in this assay, from the lowest: compound 1; then compound 4; then compounds 2 and 3 (each within the scatter of the next).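

In this assay the aryl group on the amine nitrogen gives a third level: a number 30.7 percentage points lower from compound 3 to compound 4 (beyond the scatter), a number 24 percentage points lower from compound 2 to compound 4 (beyond the scatter), and yet a number 30 percentage points higher from compound 1 to compound 4 (beyond the scatter). 2-(Trifluoromethyl)phenyl therefore separates from 4-nitrophenyl and 4-methoxyphenyl, while 3,5-dichlorophenyl still gives the lowest number of the four. No measurement offered here accounts for this order. Going by these compounds, whether an unsubstituted phenyl or a pyridyl on that nitrogen would fall nearer compound 1 or nearer compound 2 and compound 3 stays open.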